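Methoxy in Place of Chloro, Read on Two Cores

A few compounds are considered here, and "the series" means these few. Any claim that something is new, unique, unknown or untested is made for them only; others in the source may bear on it.

Compound 1 `COCOc1cc(/C=C/C(=O)OCC(=O)Nc2ccc(OC)cc2)ccc1OCc1ccccc1` is tested in a functional assay on CNE cells (Homo sapiens) for cytotoxicity, read by MTT assay, with a stated time of 72 h (a lower number here means a stronger inhibitor, a higher number a weaker inhibitor), and gives > 200000 nM, which is a limit of the assay rather than a number. Compound 2 `COCOc1cc(/C=C/C(=O)OCC(=O)Nc2ccc(Cl)cc2)ccc1OCc1ccccc1` gives > 200000 nM in this assay, again a limit. The change between them is methoxy in place of chloro on an aromatic carbon, and the step it makes is a step that the two limits leave unreadable from compound 2 to compound 1; its size stays hidden owing to the limit of > 200000 nM in this assay, at which 2 of the 3 values shown sit. Compound 3 `O=C(COC(=O)/C=C/c1ccc(O)c(O)c1)Nc1ccc(Cl)cc1` has a different core, and how that core differs from the core of compound 2 is not broken down here. In this assay, within the data shown here, compound 3 gives 89600 nM, the only plain number among the three measured compounds.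

Compound 4 `COc1ccc(NC(=O)COC(=O)/C=C/c2ccc(O)c(O)c2)cc1` awaits measurement. Among the measured compounds shown here, it differs from compound 3 by methoxy in place of chloro on an aromatic carbon, the same kind of change as the one made from compound 2 to compound 1, at a place described in the same words. Since the earlier step could not be read, the step is expected to be modest, a 1.2-fold higher number from compound 3 to compound 4 (0.09 log units; within the scatter). For compound 4 the estimate in this assay is 110000 nM, expected to fall between 40000 nM and 300000 nM.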

Compound 4, half-maximal inhibitory concentration: > 200000 nM
Compound 4 ended at the assay's limit; the forecaster's own chance of this, stated with the estimate: 30%; middle value at least 1.8-fold (0.25 log units) away from the limit.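

In this assay, methoxy in place of chloro on the core of compound 3 gives an at least 2.2-fold higher number from compound 3 to compound 4 (0.34 log units; beyond the scatter), so on this core the change goes with a weaker result. Compound 4 gives > 200000 nM, which is a limit of the assay and not a number; the step therefore has a known minimum but no known full size. The same change on the core of compound 2 cannot be read, so the data do not show that the step carries from one core to the other, only that the two cores give no conflicting reading: the limit of > 200000 nM in this assay, at which 3 of the 4 values shown sit.

From the compounds shown here alone, only chloro and methoxy appear at this place, so it remains open how an amine or a carboxylic acid there would compare with the chloro of compound 3. Going by these compounds, it also remains open how large the step would be on each core if both members of each pair gave a plain number.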